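The source may report more compounds than this note shows. Statements on the series, on what has been measured and on what is new or still open speak of the compounds shown alone.

This piece follows a single change in structure, from compound 3 to compound 4, and asks what it should do to the reading in an ADME assay on HeLa cells (Homo sapiens) for cytotoxicity, read by microscopy, with a stated time of 6 days; on this read-out higher numbers stand for lower toxicity in this test and lower numbers for higher toxicity in this test.

Of the compounds shown here, three have been measured. Compound 1, `CC(C)(C)OC(=O)N1CCC2(CC1)N=C(N)N=C(N)N2Cc1cccc(Cl)c1`, gives > 100000 nM in this assay, which is a limit of the assay and not a number. Compound 2, `CCCN1C(N)=NC(N)=NC12CCN(C(=O)C1CC1)CC2`, gives > 100000 nM in this assay, again a limit. Compound 3, `COCCN1C(N)=NC(N)=NC12CCN(C(=O)C1CC1)CC2`, gives > 100000 nM in this assay, also a limit. Going by the values given here, the one measured step, a step that the two limits leave unreadable from compound 2 to compound 3, therefore has no readable size, and all three values sit at the limit of > 100000 nM in this assay, at which 3 of the 3 values shown sit.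

Compound 4, `COCCN1C(N)=NC(N)=NC12CCN(C(=O)c1cccn1C)CC2`, differs from compound 3 by 1-methyl-1H-pyrrol-2-yl in place of cyclopropyl on a carbonyl carbon. No measured step involves a change of this kind, so nothing shown speaks for or against it. What is shown is that every compound of the shared core so far has stayed at the limit in this assay.

On that footing, compound 4 is expected to stay at the limit as well, with a step that the limit leaves unreadable from compound 3 to compound 4 that is expected to be unreadable. The estimate for compound 4 in this assay is 150000 nM, with a range from 50000 nM to 500000 nM.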

Compound 4, minimum cytotoxic concentration: > 100000 nM
Compound 4 was reported as a limit; the forecaster's own chance of this, stated with the estimate: 85%; the middle value does not contradict the limit.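

In this assay compound 4 gives > 100000 nM, a limit of the assay and not a number. Compound 3 is also reported only as a limit, so no size can be read for the change between compound 3 and compound 4, and the picture stays the same: the limit of > 100000 nM in this assay, at which 4 of the 4 values shown sit. The compounds shown leave open which change to the shared core, if any, would bring a measurable toxic concentration in this test.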